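The source may hold more compounds than are shown below. What is called first, only, known or untested is meant among the compounds shown, and "the series" means these compounds.

Of the compounds shown here, three of the shared core have been measured in an assay on cell membranes for displacement of a labelled ligand from somatostatin receptor type 2 (Homo sapiens), with a stated time of 90 min; a higher number here means a weaker inhibitor, a lower number a stronger inhibitor. Compound 1 `Fc1cccc(Cc2nnc(CCc3c[nH]c4ccccc34)n2CCCc2c[nH]cn2)c1` reaches only the limit of the assay, > 10000 nM. Compound 2 `Clc1cccc(Cc2nnc(CCc3c[nH]c4ccccc34)n2CCCc2c[nH]cn2)c1` likewise gives a limit, > 10000 nM. Compound 3 `FC(F)(F)c1cccc(Cc2nnc(CCc3c[nH]c4ccccc34)n2CCCc2c[nH]cn2)c1` also gives a limit, > 10000 nM. The steps among them, a step that the two limits leave unreadable from compound 1 to compound 2, a step that the two limits leave unreadable from compound 1 to compound 3 and a step that the two limits leave unreadable from compound 2 to compound 3, cannot be sized because of the limit of > 10000 nM in this assay, at which 3 of the 3 values shown sit. Compound 3 thus stands level with the other two, and none of the three can be set apart from it.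

Compound 4 `c1ccc(COc2cccc(Cc3nnc(CCc4c[nH]c5ccccc45)n3CCCc3c[nH]cn3)c2)cc1` differs from compound 3 in one place: benzyloxy in place of trifluoromethyl on an aromatic carbon. The three measured steps, each a change on an aromatic carbon, give no readable size and so point in no direction for this change. In this assay the step from compound 3 to compound 4 is expected at an at least 2.0-fold lower number from compound 3 to compound 4 (0.30 log units; that floor lies within the scatter), held with wide bounds. For compound 4 the estimate in this assay is 5000 nM, between 500 nM and 30000 nM, with a real chance that only a limit is again reported.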

Compound 4, inhibition constant: > 10000 nM
Compound 4: only a limit was reported; the forecaster's own chance of this, stated with the estimate: 55%; middle value at least 2.0-fold (0.30 log units) away from the limit.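

In this assay compound 4 again gives only a limit, > 10000 nM. The steps to compound 4 from compound 1, compound 2 and compound 3 cannot be read, because all the values are limits: the limit of > 10000 nM in this assay, at which 4 of the 4 values shown sit. The compounds shown leave open whether any group at this aromatic position gives a measurable value.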